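From 2,6-dichlorophenyl to 2-chlorophenyl on a shared core

The source may hold more compounds than are shown below. What is called first, only, known or untested is meant among the compounds shown, and "the series" means these compounds.

Measured in a functional assay on HCT-116 cells (Homo sapiens) for antiproliferative activity, read by MTT assay, with a stated time of 48 h (a lower number here means a stronger inhibitor, a higher number a weaker inhibitor), as follows:
Compound 1 `C#CCOc1ccc(/C=C/C(C)=O)cc1OC` gives 49700 nM as its value
Compound 2 `COc1cc(/C=C/C(C)=O)ccc1OCc1cn(-c2ccc(/N=N/c3ccccc3)cc2)nn1` gives > 100000 nM as a limit of the assay and not a number
Compound 3 `COc1cc(/C=C/C(C)=O)ccc1OCc1cn(-c2c(Cl)cccc2Cl)nn1` gives 2000 nM as its value

Only two of these results are true numbers, and compound 3 holds the lower one. Compound 1 stands higher by a gap well beyond the usual scatter of repeated measurements. Compound 3 is therefore the natural starting point for the next comparison.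

Compound 4 `COc1cc(/C=C/C(C)=O)ccc1OCc1cn(-c2ccccc2Cl)nn1` keeps the shared core and changes in one place only: hydrogen in place of chloro on an aromatic carbon in plain terms. Hydrogen replaces chloro on an aromatic carbon, ortho to a large group and meta to a chloro group, which turns 2,6-dichlorophenyl into 2-chlorophenyl.

Going by the values given here, no measured pair here shows what this swap does, so any expectation is uncertain. Compound 3 sits at the low end of the series with 2000 nM on record, so a close relative is more likely to land higher than lower. The expected change is a 2.5-fold higher number from compound 3 to compound 4 (0.40 log units; beyond the scatter) in this assay and it is a modest move toward a weaker inhibitor. For compound 4 the estimate is 5000 nM with 1200 nM to 25000 nM as the expected range.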

Compound 4, half-maximal inhibitory concentration: 39000 nM
Compound 4: the middle estimate sits 7.8-fold (0.89 log units) below what was measured; the measured number lies above the stated range.
By their numbers in this assay, from the lowest: compound 3; then compounds 4 and 1 (each within the scatter of the next). At a limit, above all of these: compound 2.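

Going by these compounds alone, this is the first pair that differs in one place only, and in this assay going from 2,6-dichlorophenyl to 2-chlorophenyl gives a 20-fold higher number from compound 3 to compound 4 (1.29 log units; beyond the scatter), a large move toward a weaker inhibitor. A single chloro group at this place, one heavy atom with no hydrogen-bond donor, no hydrogen-bond acceptor and no net charge, therefore matters a great deal on this shared core: with hydrogen in its place, most of the strength seen in compound 3 is gone. Nothing measured here speaks to why so small a change has so large an effect.

The compounds shown carry only chloro or hydrogen at this place, so it stays open whether another group, such as fluoro, methyl or methoxy, could match or improve on compound 3. A single pair also cannot tell what happens when the remaining chloro group is replaced by hydrogen as well, leaving plain phenyl, or whether a step of this size would recur on a different core.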